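The source may report more compounds than this note shows. Statements on the series, on what has been measured and on what is new or still open speak of the compounds shown alone.

Of the compounds shown here, three have so far been measured in an assay on isolated protein for inhibition of liver carboxylesterase 1 (Homo sapiens); a higher number here means a weaker inhibitor, a lower number a stronger inhibitor. Compound 1 `O=C(CCCCCCc1ccccc1)c1nc(-c2ccccn2)no1` gives 30 nM in this assay, and compound 2 `O=C(CCCCCCc1ccccc1)c1nncs1` gives 100 nM. Compound 3 `COC(=O)c1cccc(-c2ccc(C(=O)CCCCCCc3ccccc3)nn2)n1` keeps the ketone with the six-carbon chain to phenyl but carries a different core. In this assay compound 3 reaches only a limit, > 100000 nM, so no number exists for it. For the measured compounds named here, its standing is therefore given by the limit of > 100000 nM in this assay, at which 1 of the 3 values shown sits, alone: compound 3 is the one value that sits there, while compounds 1 and 2 are reported as numbers.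

Compound 4 `N#Cc1cccc(-c2ccc(C(=O)CCCCCCc3ccccc3)nn2)n1` differs from compound 3 in a single place: cyano in place of methoxycarbonyl on an aromatic carbon. Going by the values given here, no step between two measured compounds is available, so the size of such a change has no precedent in these data, and compound 3 itself offers only a limit to start from. The expected step from compound 3 to compound 4 is accordingly set as an at least 2.0-fold lower number from compound 3 to compound 4 (0.30 log units; that floor lies within the scatter), meaning a modest gain toward a measurable number rather than none. Compound 4 is expected to give about 50000 nM in this assay, with a range from 5000 nM to 300000 nM.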

Compound 4, half-maximal inhibitory concentration: 12000 nM
Beside the measured number, compound 4's estimate is 4.2-fold (0.62 log units) above it; measured number inside the range.
By their numbers in this assay, from the lowest: compound 1; then compound 2; then compound 4. At a limit, above all of these: compound 3.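

Cyano in place of methoxycarbonyl, on an aromatic carbon next to the ring nitrogen of the six-membered ring, gives an at least 8.3-fold lower number from compound 3 to compound 4 (0.92 log units; beyond the scatter) in this assay. For the compounds shown here, this is the first step between two measured compounds, and it shows that this position is not silent: changing this one group, with the ketone and the six-carbon chain to phenyl left as they are, brings a compound from a limit to a real number, by a margin beyond the usual scatter. The true size of the step remains unknown, as it has only a floor, and compound 3 is held at a limit and not at a number: the limit of > 100000 nM in this assay, at which 1 of the 4 values shown sits.

On these data alone, it remains open whether the gain comes from the cyano group itself or simply from the loss of methoxycarbonyl, and whether a carboxylic acid, an amine, an amide or a plain hydrogen on the same carbon would give a lower or a higher number than compound 4. Compounds 1 and 2 carry other cores and have no such position, so they cannot settle how far this change would carry over to them.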